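The source may hold more compounds than are shown below. What is called first, only, known or untested is meant among the compounds shown, and "the series" means these compounds.

The shared core of these compounds carries a variable side group on a saturated chain carbon bound to an aromatic nitrogen. In compound 1 `CN1CCN(CCCCCn2c3c(c4ccccc42)C(=O)c2c[n+]([O-])c4ccccc4c2C3=O)CC1` that group is 4-(4-methylpiperazin-1-yl)butyl, and in a functional assay on MDA-MB-231 cells (Homo sapiens) for cytotoxicity, read by MTT assay, with a stated time of 72 h (on this read-out higher numbers stand for weaker inhibition and lower numbers for stronger inhibition), compound 1 gives 2270 nM. Compound 2 `O=C1c2c[n+]([O-])c3ccccc3c2C(=O)c2c1c1ccccc1n2Cc1cn(C[C@@H](O)CO)nn1` and compound 3 `O=C1c2c[n+]([O-])c3ccccc3c2C(=O)c2c1c1ccccc1n2Cc1cn(CC(O)CO)nn1` carry 1-(2,3-dihydroxypropyl)-1H-1,2,3-triazol-4-yl instead; compound 2 gives 670 nM and compound 3 gives 1290 nM. Compound 3 stands second highest of the three numbers, and both its neighbours sit within the scatter: a 1.9-fold higher number from compound 2 to compound 3 (0.28 log units; within the scatter), the two being drawn differently only in configuration (the fact that one of compounds 2 and 3 is drawn with a defined configuration and the other without, at the place where they differ).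

Compound 4 `O=C1c2c[n+]([O-])c3ccccc3c2C(=O)c2c1c1ccccc1n2CCCCN1CCCCC1` carries 3-(piperidin-1-yl)propyl: 3-(piperidin-1-yl)propyl in place of 1-(2,3-dihydroxypropyl)-1H-1,2,3-triazol-4-yl on a saturated chain carbon bound to an aromatic nitrogen. Going by the values given here, the steps that bear on this change ran the other way, replacing a chain ending in a saturated ring nitrogen with the triazolyl diol: a 3.4-fold lower number from compound 1 to compound 2 (0.53 log units; beyond the scatter) and a 1.8-fold lower number from compound 1 to compound 3 (0.25 log units; within the scatter). Reversing that exchange from compound 3 suggests a slightly higher number, close to compound 1, yet not clearly beyond the scatter. Compound 4 is therefore expected to give 2000 nM, with a plausible range from 800 nM to 5000 nM, meaning an expected step of a 1.6-fold higher number from compound 3 to compound 4 (0.19 log units; within the scatter).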

Compound 4, half-maximal inhibitory concentration: 610 nM
Beside the measured number, compound 4's estimate is 3.3-fold (0.52 log units) above it, and the stated range ends above it.
By their numbers in this assay, from the lowest: compounds 4, 2, 3 and 1 (each within the scatter of the next, the first and the last beyond it).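

In this assay, putting piperidin-1-yl in place of (4-methylpiperazin-1-yl)methyl gives a 3.7-fold lower number from compound 1 to compound 4 (0.57 log units; beyond the scatter) and shows that a chain ending in a saturated ring nitrogen need not sit at the high end of this series. Against the triazolyl diol, the outcome depends on the reference compound, with a 2.1-fold lower number from compound 3 to compound 4 (0.33 log units; beyond the scatter) but only a 1.1-fold lower number from compound 2 to compound 4 (0.04 log units; within the scatter) as the other comparison. The two references differ in a single respect: the fact that one of compounds 2 and 3 is drawn with a defined configuration and the other without, at the place where they differ.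

In the step from compound 1 to compound 4, the end ring and the chain length change together, so the compounds shown leave open how much each contributes. Also open, from the compounds shown here alone, is how a morpholine ring or a dimethylamino group would read at the end of the chain in compound 4.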